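A few compounds are considered here, and "the series" means these few. Any claim that something is new, unique, unknown or untested is made for them only; others in the source may bear on it.

Measured in an ADME assay on FHC cells (Homo sapiens) for cytotoxicity, read by resazurin assay, with a stated time of 48 h; a higher number here means that more compound is tolerated, a lower number that less compound is tolerated:
- compound 1 `O=S(=O)(Nc1ccc(-c2nc3cc(NS(=O)(=O)c4cccc(C(F)(F)F)c4)ccc3o2)cc1)c1cccc(C(F)(F)F)c1`: 56000 nM
- compound 2 `O=S(=O)(Nc1ccc(-c2nc3cc(NS(=O)(=O)c4ccc(Cl)s4)ccc3o2)cc1)c1ccc(Cl)c(C(F)(F)F)c1`: 63000 nM
- compound 3 `O=S(=O)(Nc1ccc(-c2nc3cc(NS(=O)(=O)c4ccc(Br)cc4)ccc3o2)cc1)c1ccc(Br)cc1`: 18000 nM

Compound 2 at 63000 nM cannot be told apart from compound 1 at 56000 nM, as the two lie within the scatter of each other. Compound 3 at 18000 nM lies lower than both, and its gap to compound 2 is beyond the scatter.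

The next compound to read is compound 4 `O=S(=O)(Nc1ccc(-c2nc3cc(NS(=O)(=O)c4ccc(Cl)s4)ccc3o2)cc1)c1ccc(Cl)s1`. It differs from compound 2 by 5-chlorothiophen-2-yl in place of 4-chloro-3-(trifluoromethyl)phenyl on a sulfonyl sulfur. Among the measured compounds shown here, no measured pair isolates this change, and the three compounds differ from one another in more than one place, so the data give no direct size for it. In this assay only a small downward step is expected, probably not beyond the scatter. The expected range is set to start near compound 3 at 18000 nM, and the upper end allows for a value somewhat past compound 2 at 63000 nM. The estimated change is a 1.6-fold lower number from compound 2 to compound 4 (0.20 log units; within the scatter). For compound 4 the estimated value is 40000 nM, with an expected range of 16000 nM to 90000 nM.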

Compound 4, half-maximal cytotoxic concentration: 43000 nM
Beside the measured number, compound 4's estimate is 1.1-fold (0.03 log units) below it; low and high end bracket the measured number.
By their numbers in this assay, from the lowest: compound 3; then compounds 4, 1 and 2 (each within the scatter of the next).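

Among the compounds shown here, the exchange of 4-chloro-3-(trifluoromethyl)phenyl for 5-chlorothiophen-2-yl, on a sulfonyl sulfur whose other neighbour is a sulfonamide nitrogen, is the first change that can be read alone, and in this assay it gives a 1.5-fold lower number from compound 2 to compound 4 (0.17 log units; within the scatter) as its size. At this position, the two groups are therefore not separated by this read-out, even though the group that leaves has a six-membered aromatic ring of carbon only and three fluorine atoms, while the group that enters has a five-membered aromatic ring with one hetero atom. Nothing measured here bears on why the step is this size, so it stands as an observation only.

As far as these compounds go, whether this position also tolerates a change of a different kind remains open, for example a primary amine or a carboxylic acid on the ring in place of the chlorine. Compound 3 at 18000 nM has no partner differing from it in one place, so that number cannot yet be traced to either sulfonyl group or to the bromine atoms it carries.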